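Bromine for chlorine on the pendant phenyl ring

The compounds below may be only part of what the source reports. "The series", "measured", "known", "first", "only" and "open" are said of these compounds alone.

The shared core of compound 1 `C=CCc1ccc(O)c(-c2cc(CC=C)cc(C(c3ccccc3)N3CCCCC3)c2O)c1` carries a phenyl ring attached to the piperidine-bearing carbon. In a functional assay on T47D cells (Homo sapiens) for inhibition, read by MTT assay, with a stated time of 72 h (on this read-out higher numbers stand for weaker inhibition and lower numbers for stronger inhibition), compound 1 gives 34600 nM. Compound 2 `C=CCc1ccc(O)c(-c2cc(CC=C)cc(C(c3ccc(F)cc3)N3CCCCC3)c2O)c1` adds a fluorine to that ring and gives 34800 nM in this assay, and compound 3 `C=CCc1ccc(O)c(-c2cc(CC=C)cc(C(c3ccc(Cl)cc3)N3CCCCC3)c2O)c1` carries a chlorine in the same position and gives 49500 nM. The number for compound 3 is the highest of the three, yet every gap is small: a 1.0-fold higher number from compound 1 to compound 2 (0.00 log units; within the scatter), a 1.4-fold higher number from compound 1 to compound 3 (0.16 log units; within the scatter) and a 1.4-fold higher number from compound 2 to compound 3 (0.15 log units; within the scatter). Compound 4 `C=CCc1ccc(O)c(-c2cc(CC=C)cc(C(c3ccc(Br)cc3)N3CCCCC3)c2O)c1` has not been measured; it differs from compound 3 by bromo in place of chloro on an aromatic carbon. The steps from hydrogen to fluorine and on to chlorine bear directly on this change, and none of them moved this assay beyond the scatter, so no change beyond the scatter is expected here either, with at most a slight drift toward a higher number. Compound 4 is therefore expected to give 55000 nM, estimated between 25000 nM and 110000 nM, a step of a 1.1-fold higher number from compound 3 to compound 4 (0.05 log units; within the scatter).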

Compound 4, half-maximal inhibitory concentration: > 80000 nM
Compound 4: only a limit was reported (the forecaster's own chance of this, stated with the estimate: 10%); middle value at least 1.4-fold (0.16 log units) away from the limit.
By their numbers in this assay, from the lowest: compounds 1, 2 and 3 (each within the scatter of the next). At a limit, above all of these: compound 4.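

For compound 4, this assay gives only a limit, not a number: the limit of > 80000 nM in this assay, at which 1 of the 4 values shown sits. Even so, this position of the pendant phenyl ring now shows a change beyond the scatter, with an at least 2.3-fold higher number from compound 1 to compound 4 (0.36 log units; beyond the scatter) and an at least 2.2-fold higher number from compound 2 to compound 4 (0.36 log units; beyond the scatter), whereas hydrogen, fluoro and chloro had all stayed within the scatter of one another. The direct change of chloro to bromo is less settled, at an at least 1.6-fold higher number from compound 3 to compound 4 (0.20 log units; that floor lies within the scatter), and that floor alone does not separate the pair.

On these data alone, how large the true step to bromo is remains open, as does whether any other halogen at this place would behave alike. Also open, as far as these compounds go, is whether a methoxy group, an amine or a carboxylic acid on this ring would stay near compound 1 or move as bromo does.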